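Para-Substituent Swap on a Methylene Lactone Series

The compounds below may be only part of what the source reports. "The series", "measured", "known", "first", "only" and "open" are said of these compounds alone.

Compound 1 `C=C1C(=O)OC(C)CC1c1ccc([N+](=O)[O-])cc1`: 3420 nM
Compound 2 `C=C1C(=O)OC(C)CC1c1ccc(Br)cc1`: 4510 nM

In a functional assay on NALM-6 cells (Homo sapiens) for cytotoxicity, read by MTT assay, with a stated time of 48 h (a higher number here means a weaker inhibitor, a lower number a stronger inhibitor), compound 2 gives the higher of the two numbers, and its nearest neighbour is compound 1, the step from which is a 1.3-fold higher number from compound 1 to compound 2 (0.12 log units; within the scatter). Compound 3 `C=C1C(=O)OC(C)CC1c1ccc(OC)cc1` differs from compound 2 by methoxy in place of bromo on an aromatic carbon. Going by the values given here, the only measured step, from compound 1 to compound 2, changed the para group and stayed within the scatter, so no step beyond the scatter is expected in this assay here either. Compound 3 is accordingly estimated at 5000 nM (range 2000 nM to 13000 nM), a step of a 1.1-fold higher number from compound 2 to compound 3 (0.04 log units; within the scatter) that is expected to remain within the scatter.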

Compound 3, half-maximal inhibitory concentration: 5760 nM
Estimate against measurement, compound 3: 1.2-fold (0.06 log units) below; low and high end bracket the measured number.
By their numbers in this assay, from the lowest: compounds 1, 2 and 3 (each within the scatter of the next).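

In this assay, methoxy in place of bromo on an aromatic carbon gives a 1.3-fold higher number from compound 2 to compound 3 (0.11 log units; within the scatter), and methoxy in place of nitro gives a 1.7-fold higher number from compound 1 to compound 3 (0.23 log units; within the scatter). Both steps lie within the scatter, so at this place, para to a group of 9 heavy atoms, nitro, bromo and methoxy cannot be told apart in this assay, including a group with a hydrogen-bond acceptor in place of bromo with none. No measurement shown here speaks to what lies behind these numbers. From the compounds shown here alone, whether an amine, a carboxylic acid or a longer chain at this place would move the number beyond the scatter remains open.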